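Taking the iodo group off a compound at the limit

This account rests on a few compounds, and the source may have more. Where it says the series, first, only, none or still open, it means among the compounds named here.

In an ADME assay on L1210/0 cells (Mus musculus) for cytotoxicity, with a stated time of 48 h (a higher number here means a weaker inhibitor, a lower number a stronger inhibitor), compound 1 `Nc1ncnc2c1nnn2[C@@H]1C[C@H](CO)[C@@H](CO)[C@H]1CO` gives > 200000 nM, which is a limit and not a number. Compound 2 `CCOc1ncnc2c1ncn2C[C@@H]1C[C@H](CO)c2ccccc21` gives > 200000 nM, which is also a limit. Compound 3 `O=c1[nH]c(=O)n(CC2CCC(CO)C2)cc1I` gives > 200000 nM, and this too is a limit. Compound 3 therefore stands with the other two, as the limit of > 200000 nM in this assay, at which 3 of the 3 values shown sit. Among the compounds with values here, none of these three compounds has an exact value, and no two of them differ in only one place, so there is no measured step to serve as a guide.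

Compound 4 `O=c1ccn(CC2CCC(CO)C2)c(=O)[nH]1` is compound 3 with a single change, hydrogen in place of iodo on an aromatic carbon. The expectation rests on compound 3 alone, whose result of > 200000 nM is a limit. No step beyond the scatter is expected in this assay, in either direction. The estimate amounts to a number no higher from compound 3 to compound 4 (the limit leaves the size open), an expected step that stays within the scatter. For compound 4 the estimated value is 200000 nM, with an expected range from 100000 nM to 400000 nM. The assay is expected to report only a limit once more.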

Compound 4, half-maximal inhibitory concentration: > 200000 nM
Compound 4 ended at the assay's limit (the forecaster's own chance of this, stated with the estimate: 90%); the middle value lies on the limit itself.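

Compound 4 gives > 200000 nM in this assay, and this is a limit. Compound 3 also rests on a limit, so no step can be read between compound 3 and compound 4. The compounds shown leave open the exact value of each and whether hydrogen in place of iodo changes it at all: the limit of > 200000 nM in this assay, at which 4 of the 4 values shown sit.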